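A few compounds are considered here, and "the series" means these few. Any claim that something is new, unique, unknown or untested is made for them only; others in the source may bear on it.

Measured compounds:
Compound 1 `COc1cc(N)c(Cl)cc1C(=O)CCC1CCN(CCNS(=O)(=O)c2cc(Br)ccc2Br)CC1` gives 16.3 nM in an assay on brain for displacement of a labelled ligand from 5-hydroxytryptamine receptor 4 (Cavia porcellus), with a stated time of 30 min, in the presence of a further agent that is not named here; a higher number here means a weaker inhibitor, a lower number a stronger inhibitor.
Compound 2 `COc1ccc(S(=O)(=O)NCCN2CCC(CCC(=O)c3cc(Cl)c(N)cc3OC)CC2)cc1Cl` gives 22.5 nM in this assay.
Compound 3 `COc1ccc(S(=O)(=O)NCCN2CCC(CCC(=O)c3cc(Cl)c(N)cc3OC)CC2)c(OC)c1` gives 18.7 nM in this assay.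

Compound 2 has the highest of the three numbers, but its steps to the others are small: a 1.2-fold lower number from compound 2 to compound 3 (0.08 log units; within the scatter) and, in the other direction, a 1.4-fold higher number from compound 1 to compound 2 (0.14 log units; within the scatter). All three compounds share the same core and differ only in the aromatic ring on the sulfonyl sulfur, and every swap there stays within the scatter, including a 1.1-fold higher number from compound 1 to compound 3 (0.06 log units; within the scatter).

Compound 4 `COc1cc(N)c(Cl)cc1C(=O)CCC1CCN(CCNS(=O)(=O)c2ccc(OC)c(N3CCN(C)CC3)c2)CC1` differs from compound 2 by 4-methylpiperazin-1-yl in place of chloro on an aromatic carbon. For the measured compounds named here, this is a larger change than any measured step: a single halogen gives way to a ring carrying two nitrogens, and no measured pair tests such a group. The measured steps show that varying the substituents on this ring has so far moved the number little, so the expectation for compound 4 is no clear shift, with wide uncertainty. Compound 4 is expected at 25 nM, between 8 nM and 80 nM, meaning an estimated step of a 1.1-fold higher number from compound 2 to compound 4 (0.05 log units; within the scatter).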

Compound 4, inhibition constant: 3.46 nM
Compound 4: the middle estimate sits 7.2-fold (0.86 log units) above what was measured; measured number below the stated range.
By their numbers in this assay, from the lowest: compound 4; then compounds 1, 3 and 2 (each within the scatter of the next).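

For the compounds shown here, replacing chloro with 4-methylpiperazin-1-yl on this aromatic carbon, ortho to a methoxy group, gives the first step in this assay that lies beyond the scatter (a 6.5-fold lower number from compound 2 to compound 4 (0.81 log units; beyond the scatter)). The earlier swaps of one halogen- or methoxy-bearing ring for another left the number within the scatter, whereas this result shows that the ring on the sulfonyl sulfur can still change the number when it carries a group with its own ring and two nitrogens. Nothing available here explains why this change goes with a stronger inhibitor.

A single step cannot show which part of the new group matters, and morpholin-4-yl or dimethylamino at this carbon would help separate the ring from its nitrogens. As far as these compounds go, the role of the methyl group also stays open, and piperazin-1-yl would test it directly.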